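A few compounds are considered here, and "the series" means these few. Any claim that something is new, unique, unknown or untested is made for them only; others in the source may bear on it.

Measured so far:
- compound 1, `CC(C)Oc1cc(-c2cncc(-c3c[nH]nc3C3CC3)c2)ccc1C(N)=O`: 130 nM
- compound 2, `CNC(=O)c1ccc(-c2cccnc2)cc1`: 292000 nM

Of the compounds shown here, two have been measured in an assay on cells for inhibition of MAP kinase-interacting serine/threonine-protein kinase 1 (Homo sapiens), read by mobility shift assay, with stated times of 10 min and 60 min, in the presence of a further agent that is not named here; a lower number here means a stronger inhibitor, a higher number a weaker inhibitor. Compound 1 gives 130 nM, the lower of the two numbers. Compound 2 gives 292000 nM, a far higher number, well beyond the usual scatter. The two structures differ in more than one place, so their values alone cannot tell which part of compound 1 carries the difference.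

Compound 3, `CC(C)Oc1cc(-c2cccnc2)ccc1C(N)=O`, has not yet been measured. It differs from compound 1 in one place: hydrogen in place of 3-cyclopropyl-1H-pyrazol-4-yl on an aromatic carbon. The group that leaves is the whole 3-cyclopropyl-1H-pyrazol-4-yl unit, so a sizeable part of compound 1 is gone. For the measured compounds named here, no single-change step between measured compounds is available to set the size; the only guide is that compound 2, which also lacks this unit, gives a much higher number. A large loss is therefore expected, so that the step of a 230-fold higher number from compound 1 to compound 3 (2.36 log units; beyond the scatter) is estimated to run well beyond the scatter toward weaker inhibition. For compound 3 the expected value in this assay is 30000 nM, in a range from 3000 nM to 300000 nM.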

Compound 3, half-maximal inhibitory concentration: 880 nM
Compound 3: the middle estimate sits 34-fold (1.53 log units) above what was measured, outside the stated range (below it).
By their numbers in this assay, from the lowest: compound 1; then compound 3; then compound 2.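

Replacing 3-cyclopropyl-1H-pyrazol-4-yl with hydrogen in this assay gives a 6.8-fold higher number from compound 1 to compound 3 (0.83 log units; beyond the scatter) and so shows that this group adds to inhibition by compound 1. Yet compound 3 still gives 880 nM in this measurement, so much of the inhibition remains without the group, and the position is helpful rather than indispensable. The data shown offer no explanation for the size of this step.

The compounds shown leave open which part of the departing unit accounts for the step, since a plain 1H-pyrazol-4-yl without the cyclopropyl ring would separate the two rings. Going by these compounds, whether a much smaller group at the same aromatic carbon, such as a methyl or an amine, would recover any of the difference also remains unknown.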